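Benzoxazole sulfonamides: dichlorophenyl replacing hydroxyphenyl

The source may hold more compounds than are shown below. What is called first, only, known or untested is meant among the compounds shown, and "the series" means these compounds.

Measured so far:
- compound 1 `Cc1ccc(S(=O)(=O)Nc2ccc3oc(-c4ccccc4)nc3c2)cc1`: in an assay on isolated protein for inhibition of malate dehydrogenase, mitochondrial (Sus scrofa), with stated times of 45 min and 30 min (a higher number here means a weaker inhibitor, a lower number a stronger inhibitor), compound 1 gives only a limit, > 63000 nM
- compound 2 `O=S(=O)(Nc1ccc2oc(-c3ccccc3)nc2c1)c1ccc(O)cc1`: in this assay compound 2 gives only a limit, > 63000 nM

Both values sit at the limit of > 63000 nM in this assay, at which 2 of the 2 values shown sit, so the step that the two limits leave unreadable from compound 1 to compound 2 cannot be read. Compound 2 thus stands only at a limit, with no number. The next member is compound 3 `O=S(=O)(Nc1ccc2oc(-c3ccccc3)nc2c1)c1ccc(Cl)c(Cl)c1`, which differs from compound 2 by 3,4-dichlorophenyl in place of 4-hydroxyphenyl on a sulfonyl sulfur. For the measured compounds named here, no measured step bears on this change, and the single step in the set is itself unreadable. Compound 3 is therefore expected to give 40000 nM, in the range 8000 nM to 100000 nM. The step of an at least 1.5-fold lower number from compound 2 to compound 3 (0.19 log units; that floor lies within the scatter) is the estimate implied, most likely again ending at a limit.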

Compound 3, half-maximal inhibitory concentration: > 63000 nM
Compound 3 was reported as a limit; the forecaster's own chance of this, stated with the estimate: 60%; middle value at least 1.5-fold (0.19 log units) from the limit.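

Compound 1, compound 2 and compound 3 give no readable step, as each value is only a limit: the limit of > 63000 nM in this assay, at which 3 of the 3 values shown sit.

The compounds shown leave open whether any group on the sulfonyl sulfur gives a measurable number in this assay.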